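The source may report more compounds than this note shows. Statements on the series, on what has been measured and on what is new or still open speak of the compounds shown alone.

Measured so far in an assay on isolated protein for inhibition of 2-Hydroxyacid oxidase 1 (Homo sapiens), with stated times of 30 min and 15 min; a higher number here means a weaker inhibitor, a lower number a stronger inhibitor:
- compound 1, `O=C(O)c1nnsc1Sc1ccc(Cl)cc1`: > 30000 nM
- compound 2, `CC(C)c1coc(-c2cccc(CNc3ccc4[nH]nc(C(=O)O)c4c3)c2O)n1`: 87 nM
- compound 3, `CC(C)c1csc(-c2cccc(CNc3ccc4[nH]nc(C(=O)O)c4c3)c2O)n1`: 65 nM

Compound 1 gives > 30000 nM, which is a limit of the assay and not a number. Among the remaining two numbers, compound 3 stands together with compound 2: the step of a 1.3-fold lower number from compound 2 to compound 3 (0.13 log units; within the scatter) is within the scatter, so the two cannot be told apart.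

Compound 4, `Cc1cccc(CNc2ccc3[nH]nc(C(=O)O)c3c2)c1O`, differs from compound 3 in one place: methyl in place of 4-isopropyl-1,3-thiazol-2-yl on an aromatic carbon. No measured step removes this group; the only step shown, a 1.3-fold lower number from compound 2 to compound 3 (0.13 log units; within the scatter), swaps one five-membered aromatic ring for a closely related one and changes little. That step therefore says nothing about taking the ring away altogether. Since a group of eight heavy atoms is replaced by a single carbon, a weaker result is expected rather than none. For compound 4 the estimate is 800 nM, with a likely range of 150 nM to 5000 nM; this corresponds to an expected step of a 12-fold higher number from compound 3 to compound 4 (1.09 log units; beyond the scatter).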

Compound 4, half-maximal inhibitory concentration: 17000 nM
Compound 4: the middle estimate sits 21-fold (1.33 log units) below what was measured; measured number outside the range, above it.
By their numbers in this assay, from the lowest: compounds 3 and 2 (each within the scatter of the next); then compound 4. At a limit, above all of these: compound 1.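

Going by these compounds alone, the earlier pair only exchanged one five-membered aromatic ring for another on this carbon, ortho to a hydroxy group, and that exchange stayed within the scatter; compound 4 is the first to lose the ring altogether. In this assay methyl in place of 4-isopropyl-1,3-thiazol-2-yl gives a 260-fold higher number from compound 3 to compound 4 (2.42 log units; beyond the scatter) and methyl in place of 4-isopropyl-1,3-oxazol-2-yl gives a 200-fold higher number from compound 2 to compound 4 (2.29 log units; beyond the scatter), both large steps. Among these compounds, then, low numbers occur only with one of the two ring groups on this carbon, whichever of the two it is.

As far as these compounds go, whether the ring without its isopropyl, or an ethyl group or a phenyl ring on this carbon, would recover part of the loss remains open. Nothing measured here explains why the loss is so large.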